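The compounds below may be only part of what the source reports. "The series", "measured", "known", "first", "only" and "open" are said of these compounds alone.

Of the compounds shown here, three sharing one core have been tested in a functional assay on the whole organism for inhibition, with Rattus norvegicus as the target, read by paw edema, with stated times of 30 min and 3 h, at a dose of 0.28 mmol/kg by the oral route; a higher number here means more inhibition at the dose given (going by the name of the read-out), a lower number less inhibition. Compound 1, `CCNC(=O)c1nc(-c2cc(OC)c(OC)c(OC)c2)n(-c2ccc(OC)cc2)n1`, carries an ethyl group on the amide nitrogen and gives 88%. Compound 2, `COc1ccc(-n2nc(C(=O)Nc3ccccc3C)nc2-c2cc(OC)c(OC)c(OC)c2)cc1`, gives 64%, and compound 3, `COc1ccc(-n2nc(C(=O)Nc3cccc(F)c3)nc2-c2cc(OC)c(OC)c(OC)c2)cc1`, gives 92%. The steps among them are modest: a number 24 percentage points lower from compound 1 to compound 2 (beyond the scatter), while a number 4 percentage points higher from compound 1 to compound 3 (within the scatter), and a number 28 percentage points higher from compound 2 to compound 3 (beyond the scatter). Compound 3 thus gives the top number of the three, but it cannot be separated from compound 1, whereas the gap to compound 2 is beyond the scatter.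

Compound 4, `COc1ccc(-n2nc(C(=O)Nc3ccccc3)nc2-c2cc(OC)c(OC)c(OC)c2)cc1`, is the unmeasured member. It differs from compound 3 only in that (hydrogen in place of fluoro on an aromatic carbon). The measured steps bearing on this change are those at the amide nitrogen: the step from compound 2 to compound 3 reshuffled the substitution of the aryl group and moved the number by a modest amount, while ethyl and 3-fluorophenyl, compounds 1 and 3, stayed within the scatter of each other. Loss of a single fluoro is a smaller change than either, so the step from compound 3 to compound 4 is expected to be a number 8 percentage points lower from compound 3 to compound 4 (within the scatter), within the scatter or slightly downward. Compound 4 is therefore estimated at 84% in this assay, with a range of 70% to 95%.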

Compound 4, a percentage reported as inhibition, in the whole organism at one dose (the size of the read-out at that dose, not a potency): 69%
Beside the measured number, compound 4's estimate is 15 percentage points above it, outside the stated range (below it).
By their numbers in this assay, from the lowest: compounds 2 and 4 (each within the scatter of the next); then compounds 1 and 3 (each within the scatter of the next).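

Within this assay, the fluoro on the aromatic carbon meta to a large group proves to matter: replacing this one heavy atom with hydrogen gives a number 23 percentage points lower from compound 3 to compound 4 (beyond the scatter), a step of the kind earlier seen only when whole groups on the amide nitrogen were exchanged. The methyl of the 2-methylphenyl group shows no such separation, since hydrogen in its place gives a number 5 percentage points higher from compound 2 to compound 4 (within the scatter), which leaves the phenyl and 2-methylphenyl amides indistinguishable at this dose. Phenyl in place of ethyl gives a number 19 percentage points lower from compound 1 to compound 4 (beyond the scatter), so an aryl group on the amide nitrogen does not by itself hold the number at the level of the ethyl amide; compound 3 keeps that level, whereas compound 2 and compound 4 do not. Nothing available explains why this single fluoro has such an effect.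

As far as these compounds go, whether a chloro, a methoxy or an amino group on the same aromatic carbon would hold the number as the fluoro does remains open. So does the question of whether a propyl or longer chain on the amide nitrogen would stay level with the ethyl group.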